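Sulfonyl aryl variation on the shared core

A few compounds are considered here, and "the series" means these few. Any claim that something is new, unique, unknown or untested is made for them only; others in the source may bear on it.

Compound 3 `COc1ccc(S(=O)(=O)N(C)c2ccc3[nH]c(-c4n[nH]c5ccccc45)cc3n2)cc1` stands at the highest of the three numbers in a functional assay on SMMC-7721 cells (Homo sapiens) for antiproliferative activity, read by MTT assay, with a stated time of 72 h (on this read-out lower numbers stand for stronger inhibition and higher numbers for weaker inhibition), where compound 3 gives 13000 nM, with compound 1 `CN(c1ccc2[nH]c(-c3n[nH]c4ccccc34)cc2n1)S(=O)(=O)c1ccc(Cl)cc1` nearest at 12700 nM and compound 2 `CN(c1ccc2[nH]c(-c3n[nH]c4ccccc34)cc2n1)S(=O)(=O)c1ccc(Br)cc1` at 11500 nM; all three lie within the scatter of one another. Compound 4 `CN(c1ccc2[nH]c(-c3n[nH]c4ccccc34)cc2n1)S(=O)(=O)c1cccc([N+](=O)[O-])c1` carries 3-nitrophenyl in place of 4-methoxyphenyl on a sulfonyl sulfur. Within the data shown here, the steps that bear on this are a 1.0-fold higher number from compound 1 to compound 3 (0.01 log units; within the scatter) and a 1.1-fold higher number from compound 2 to compound 3 (0.05 log units; within the scatter), and also a 1.1-fold lower number from compound 1 to compound 2 (0.04 log units; within the scatter): every swap on this ring so far stayed within the scatter in this assay. Among the measured compounds shown here, a 3-nitrophenyl group has no measured precedent here, so the expectation rests on those flat steps; for compound 4 no step beyond the scatter is expected, a 1.0-fold lower number from compound 3 to compound 4 (0.02 log units; within the scatter). Compound 4 is estimated at 12500 nM, in the range 5000 nM to 32000 nM.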

Compound 4, half-maximal inhibitory concentration: 5070 nM
The estimate for compound 4 lay 2.5-fold (0.39 log units) above the measured number; the measured number falls inside the stated range.
By their numbers in this assay, from the lowest: compound 4; then compounds 2, 1 and 3 (each within the scatter of the next).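

In this assay, this position on a sulfonyl sulfur can shift the number beyond the scatter: a 2.6-fold lower number from compound 3 to compound 4 (0.41 log units; beyond the scatter), a 2.3-fold lower number from compound 2 to compound 4 (0.36 log units; beyond the scatter) and a 2.5-fold lower number from compound 1 to compound 4 (0.40 log units; beyond the scatter). Compound 4 alone stands apart, whereas compounds 1, 2 and 3 remain within the scatter of one another. No available evidence bears on this result.

Open, on these data alone, is whether the lower number follows the nitro group or its place on the ring, which a 4-nitrophenyl or 3-methoxyphenyl group would separate. As far as these compounds go, how an amine or a carboxylic acid on this ring would read also remains open.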